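This account rests on a few compounds, and the source may have more. Where it says the series, first, only, none or still open, it means among the compounds named here.

Compound 1 `COc1ccc2[nH]c(C(=O)N3CC(=O)N(Cc4ccccc4)[C@@H](CCc4ccccc4)C3)cc2c1`: > 30000 nM
Compound 2 `COc1ccc2[nH]c(C(=O)N3CC(=O)N(c4ccccc4)[C@@H](Cc4ccccc4)C3)cc2c1`: > 30000 nM

In an ADME assay on Vero cells (Chlorocebus sabaeus) for cytotoxicity, with a stated time of 7 days (a higher number here means that more compound is tolerated, a lower number that less compound is tolerated), compound 1 gives > 30000 nM, which is a limit of the assay rather than a number. Compound 2 likewise gives > 30000 nM, also a limit. Within the data shown here, both values sit at the same boundary (the limit of > 30000 nM in this assay, at which 2 of the 2 values shown sit), so compound 1 stands level with the only other compound measured here. Compound 3 `COc1ccc2[nH]c(C(=O)N3CC(=O)N(Cc4ccccc4)[C@@H](CN4CC5CCCCC5C4)C3)cc2c1` differs from compound 1 in one place: a group of 9 heavy atoms (8 carbon, 1 nitrogen; one five-membered non-aromatic ring with 1 hetero atom, one six-membered non-aromatic ring of carbon only) in place of a group of 7 heavy atoms (7 carbon; one six-membered aromatic ring of carbon only), on a saturated chain carbon bound to a saturated ring carbon. Among the measured compounds shown here, no measured step bears on this change, so no shift beyond the usual scatter is expected. The step in this assay is expected to be a number no higher from compound 1 to compound 3 (the limit leaves the size open). Compound 3 is estimated at 30000 nM, between 15000 nM and 60000 nM, most likely again reported only as a limit.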

Compound 3, half-maximal cytotoxic concentration: 8200 nM
Estimate against measurement, compound 3: 3.7-fold (0.56 log units) above; measured number below the stated range.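

In this assay, this place, a saturated chain carbon bound to a saturated ring carbon, proves able to move the read-out: replacing benzyl with the two-ring group carrying nitrogen gives an at least 3.6-fold lower number from compound 1 to compound 3 (0.56 log units; beyond the scatter). Compound 3 is the only compound shown with a number rather than a limit, so the step's full size stays undetermined: the limit of > 30000 nM in this assay, at which 2 of the 3 values shown sit.

Whether the nitrogen or the saturated rings account for the change remains open. On these data alone, how a plain dimethylamino or cyclohexyl group would read at this place also remains open.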